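The source may report more compounds than this note shows. Statements on the series, on what has been measured and on what is new or still open speak of the compounds shown alone.

Measured in a functional assay on U-937 cells (Homo sapiens) for cytotoxicity, read by MTT assay, with a stated time of 24 h; on this read-out higher numbers stand for weaker inhibition and lower numbers for stronger inhibition:
- compound 1 `CN1CCN(CCCCCOc2c(Br)cc(Br)cc2Oc2ccc(Br)cc2Br)CC1` gives 49.1 ug/mL
- compound 2 `BrCCCCCCOc1c(Br)cc(Br)cc1Oc1ccc(Br)cc1Br` gives 33.8 ug/mL
- compound 3 `CC(C)(C)OC(=O)N1CCN(CCCCCOc2c(Br)cc(Br)cc2Oc2ccc(Br)cc2Br)CC1` gives 35.5 ug/mL

Compound 2, at 33.8 ug/mL, sits within the scatter of both other compounds, so the three numbers form a single level with no order among them.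

The next compound is compound 4 `CC(C)(C)C(=O)C(C#N)Oc1c(Br)cc(Br)cc1Oc1ccc(Br)cc1Br`, reached from compound 2 by putting cyano((tert-butyl)carbonyl)methyl in place of 6-bromohexyl on an oxygen on an aromatic ring.

Within the data shown here, two measured steps bear on this, and only indirectly. They are a 1.5-fold lower number from compound 1 to compound 2 (0.16 log units; within the scatter) and a 1.4-fold lower number from compound 1 to compound 3 (0.14 log units; within the scatter). Both stay within the scatter, so the changes they cover, made away from the shared core, leave the number where it was. Among the measured compounds shown here, neither replaces the whole group on that oxygen, so the data hold no direct precedent for this change, and the uncertainty is wider than those steps alone suggest. No direction is supported by them, and the expectation is no step beyond the scatter.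

The expected change is a 1.1-fold lower number from compound 2 to compound 4 (0.05 log units; within the scatter), taking compound 2 as the reference point.

For compound 4 the estimated value is 30 ug/mL in this assay.

The expected range for compound 4 runs from 11 ug/mL to 65 ug/mL as an estimate.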

Compound 4, half-maximal inhibitory concentration: 32.5 ug/mL
The estimate for compound 4 lay 1.1-fold (0.03 log units) below the measured number, within the range that was stated.
By their numbers in this assay, from the lowest: compounds 4, 2, 3 and 1 (each within the scatter of the next).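

The whole group on the oxygen on an aromatic ring has now been exchanged, and in this assay this gives a 1.0-fold lower number from compound 2 to compound 4 (0.02 log units; within the scatter). The earlier steps shown here left part of the group on that oxygen in place, whereas here 6-bromohexyl, with no hydrogen-bond acceptors, gives way to cyano((tert-butyl)carbonyl)methyl, with 2 hydrogen-bond acceptors, a double bond and a triple bond outside aromatic rings, and the number still stays at the same level. Across these compounds the read-out therefore does not follow the identity of the group on this oxygen, and nothing available accounts for that flat result.

Whether the level seen so far is set by the shared core, rather than by the group on this oxygen, stays open, since no step shown moves the number beyond the scatter. A carboxylic acid or a primary amine on that oxygen, or a hydroxyl in place of the whole group, would test whether this level holds for groups unlike those shown here.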